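Replacing the Chlorobenzyl Arm with tert-Butyl

The source may hold more compounds than are shown below. What is called first, only, known or untested is meant among the compounds shown, and "the series" means these compounds.

compound 1 `CCCCc1cnc(C(C)Cc2ccc(-c3ccccc3C(=O)O)cc2)[nH]1`: 184 nM
compound 2 `CCCCc1cnc(C(Cc2ccc(-c3ccccc3C(=O)O)cc2)C(C)C)[nH]1`: 2240 nM
compound 3 `O=C(O)c1ccccc1-c1ccc(CCc2ncc(Cc3ccc(Cl)cc3)[nH]2)cc1`: 102 nM

In an in vitro functional assay on cells for agonist activity at Bombesin receptor subtype-3 (Mus musculus), read by luminescence and calcium flux (on this read-out lower numbers stand for an effect already at smaller amounts and higher numbers for an effect only at larger amounts of compound), compound 3 gives 102 nM, the lowest of the three numbers; its distance from compound 1 lies within the scatter, while compound 2 stands well beyond it. Compound 4 `CC(C)(C)c1cnc(CCc2ccc(-c3ccccc3C(=O)O)cc2)[nH]1` differs from compound 3 in one place: tert-butyl in place of 4-chlorobenzyl on an aromatic carbon. For the measured compounds named here, the only measured single-place step, a 12-fold higher number from compound 1 to compound 2 (1.09 log units; beyond the scatter), concerns a saturated chain carbon rather than the aromatic carbon of the five-membered ring, so no measured step bears directly on this change. Compound 1 and compound 3 carry different groups on that ring carbon but differ elsewhere too, so their values show only that both lie close together. Compound 4 is therefore expected to show a 3.9-fold higher number from compound 3 to compound 4 (0.59 log units; beyond the scatter), a modest weakening with wide uncertainty. Compound 4 is estimated at 400 nM, between 120 nM and 1500 nM.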

Compound 4, half-maximal effective concentration: 2750 nM
The estimate for compound 4 lay 6.9-fold (0.84 log units) below the measured number, outside the stated range (above it).
By their numbers in this assay, from the lowest: compounds 3 and 1 (each within the scatter of the next); then compounds 2 and 4 (each within the scatter of the next).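

In this assay, for the compounds shown here, the exchange on this aromatic carbon of the five-membered ring gives a 27-fold higher number from compound 3 to compound 4 (1.43 log units; beyond the scatter) and is the first measured step at this position, showing that its number is highly sensitive to the group carried there. The entering tert-butyl has no ring and 4 heavy atoms, whereas the departing 4-chlorobenzyl has a six-membered aromatic ring and 8. No measurement at hand explains the size of this step. Still open, from the compounds shown here alone, is whether plain benzyl or cyclohexylmethyl at this position would keep the lower number of compound 3, which would separate the roles of the chlorine and the aromatic ring.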